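The source may report more compounds than this note shows. Statements on the series, on what has been measured and on what is new or still open speak of the compounds shown alone.

Working notes on the series in a functional assay on PC-3 cells (Homo sapiens) for antiproliferative activity, read by sulforhodamine B assay; a lower number here means a stronger inhibitor of growth, a higher number a weaker inhibitor of growth. Going by the values given here, compound 1 `CC(C)(C)CCOc1cccc(O)c1C(=O)/C=C/c1ccc(C(=O)O)cc1` gives 6500 nM, the only reading so far that is a number. Compound 2 `CCCCCCOc1cccc(O)c1C(=O)/C=C/c1ccc(O)cc1` gives > 30000 nM, which is a limit of the assay and not a number. Compound 3 `O=C(/C=C/c1ccc(O)cc1)c1c(O)cccc1OCCC1CCCCC1` gives > 30000 nM, again a limit, so its place on the scale is known only as that limit. The two limits together make up (the limit of > 30000 nM in this assay, at which 2 of the 3 values shown sit).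

Compound 4 `CCC(CC)COc1cccc(O)c1C(=O)/C=C/c1ccc(O)cc1` is reached from compound 3 by pentan-3-yl in place of cyclohexylmethyl on a saturated chain carbon bound to an oxygen on an aromatic ring. The change is pentan-3-yl in place of cyclohexylmethyl on a saturated chain carbon bound to an oxygen on an aromatic ring, which can also be read as 2-cyclohexylethoxy to 2-ethylbutoxy. The ring of the side chain is lost, and the side chain remains all carbon.

Among the compounds with values here, the one measured step that bears on this change is a step that the two limits leave unreadable from compound 2 to compound 3, and it gives no size to carry over. With no measured size to build on, no real shift in this assay is anticipated, and a further limit is the likeliest outcome. The expected step of a number no higher from compound 3 to compound 4 (the limit leaves the size open) is estimated to stay within the scatter. Compound 4 is estimated at 30000 nM, with an expected range of 15000 nM to 60000 nM.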

Compound 4, concentration for 50% growth inhibition: 3390 nM
Compound 4: middle estimate off by 8.8-fold (0.95 log units), on the high side; the whole stated range lies above it.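

In this assay, pentan-3-yl in place of cyclohexylmethyl on a saturated chain carbon bound to an oxygen on an aromatic ring gives an at least 8.8-fold lower number from compound 3 to compound 4 (0.94 log units; beyond the scatter), so this position can move the read-out and is not silent, as the earlier limits alone might have suggested. Pentan-3-yl in place of pentyl at the same place gives an at least 8.8-fold lower number from compound 2 to compound 4 (0.94 log units; beyond the scatter), which shows that the all-carbon side chains here are not interchangeable: among these three compounds, only the chain carrying pentan-3-yl gives a number. As far as these compounds go, both steps are bounds, and their true size stays open, since each starts from a compound at a limit: the limit of > 30000 nM in this assay, at which 2 of the 4 values shown sit.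

The step between the two compounds at the limit cannot be read, so the pentyl and cyclohexylmethyl chains cannot be ranked against each other. From the compounds shown here alone, it also remains open whether the effect of pentan-3-yl extends to a longer branched chain, and how a side chain bearing an amine would behave at this position.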